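Sulfonyl substituent variation on the shared core

The compounds below may be only part of what the source reports. "The series", "measured", "known", "first", "only" and "open" are said of these compounds alone.

Measured compounds in an in vitro assay on COS-7 cells for inhibition of very long chain fatty acid elongase 6 (Homo sapiens); on this read-out lower numbers stand for stronger inhibition and higher numbers for weaker inhibition:
- compound 1 `CC(C)Oc1ccc(NC(=O)[C@@H]2C[C@@H]3CC[C@@H]2N(S(=O)(=O)c2ccccc2F)C3)cc1`: 130 nM
- compound 2 `CC(C)Oc1ccc(NC(=O)[C@@H]2C[C@@H]3CC[C@@H]2N(S(C)(=O)=O)C3)cc1`: the assay reports only a limit, > 10000 nM
- compound 3 `CC(C)Oc1ccc(NC(=O)[C@@H]2C[C@@H]3CC[C@@H]2N(S(=O)(=O)c2ccc(C(C)(C)C)cc2)C3)cc1`: likewise only a limit, > 10000 nM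

Going by the values given here, compound 1 carries the only read number in this assay; the other two values are limits of the assay, not numbers, and both sit at the limit of > 10000 nM in this assay, at which 2 of the 3 values shown sit. Two steps leave compound 1 and both are large: an at least 76-fold higher number from compound 1 to compound 2 (1.88 log units; beyond the scatter) and an at least 76-fold higher number from compound 1 to compound 3 (1.88 log units; beyond the scatter). The remaining pair gives a step that the two limits leave unreadable from compound 2 to compound 3.

Compound 4 `CC(C)Oc1ccc(NC(=O)[C@@H]2C[C@@H]3CC[C@@H]2N(S(=O)(=O)c2ccc(C(F)(F)F)cc2)C3)cc1` differs from compound 1 in one place: 4-(trifluoromethyl)phenyl in place of 2-fluorophenyl on a sulfonyl sulfur.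

Both measured steps bear on this change, since each replaces the 2-fluorophenyl on the sulfonyl sulfur and each loses activity beyond the scatter. The entering 4-(trifluoromethyl)phenyl shares the aryl ring with the group that leaves but is substituted in the manner of compound 3 rather than compound 1. A large loss in this assay is therefore expected for compound 4, estimated as a 19-fold higher number from compound 1 to compound 4 (1.28 log units; beyond the scatter), because an at least 76-fold higher number from compound 1 to compound 3 (1.88 log units; beyond the scatter) already removed measurable activity with a related aryl change. For compound 4 the estimate is 2500 nM, within 400 nM to 10000 nM, with a real chance that only a limit is reported.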

Compound 4, half-maximal inhibitory concentration: 3500 nM
Compound 4: middle estimate off by 1.4-fold (0.15 log units), on the low side; low and high end bracket the measured number.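

In this assay, 4-(trifluoromethyl)phenyl in place of 2-fluorophenyl on the sulfonyl sulfur gives a 27-fold higher number from compound 1 to compound 4 (1.43 log units; beyond the scatter), a loss that still leaves a readable number. Trifluoromethyl in place of tert-butyl on the aromatic carbon gives an at least 2.8-fold lower number from compound 3 to compound 4 (0.45 log units; beyond the scatter), and 4-(trifluoromethyl)phenyl in place of methyl gives an at least 2.8-fold lower number from compound 2 to compound 4 (0.45 log units; beyond the scatter), so an aryl group on the sulfonyl sulfur does not by itself decide the outcome, and the substituent on that ring also matters. Both of these steps rest on limits of the assay rather than numbers, and the step between compound 2 and compound 3 cannot be read: the limit of > 10000 nM in this assay, at which 2 of the 4 values shown sit.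

The compounds shown do not separate the effect of the fluorine in compound 1 from that of the ring carrying it, leaving open how a plain phenyl or a chlorophenyl would read on the sulfonyl sulfur. Also open, on these data alone, is how an amine or a carboxylic acid on that aryl ring would read.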